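The compounds below may be only part of what the source reports. "The series", "measured", "known", "first", "only" and "open" are said of these compounds alone.

Three compounds of the series carry a number in an assay on isolated protein for inhibition of alkaline phosphatase, tissue-nonspecific isozyme (Bos taurus), read by spectrophotometry, with stated times of 7 min and 15 min; a higher number here means a weaker inhibitor, a lower number a stronger inhibitor. Compound 1 `COc1ccc(C(C)n2c(-c3ccc(C)cc3)cc(=O)c3cc([N+](=O)[O-])ccc32)cc1` gives 17900 nM, compound 2 `CCCCCc1cc(=O)c2cc([N+](=O)[O-])ccc2n1Cc1ccc(OC)cc1` gives 1510 nM, and compound 3 `Cc1ccc(-c2c(Br)c(=O)c3cc([N+](=O)[O-])ccc3n2C(C)c2ccccc2)cc1` gives 1340 nM. Compound 2 stands next to compound 3, the two within the scatter of each other, and far from compound 1, whose number lies beyond the scatter on the higher side. Compound 4 `CCCCCc1c(Br)c(=O)c2cc([N+](=O)[O-])ccc2n1Cc1ccc(OC)cc1` is not yet measured. It differs from compound 2 by bromo in place of hydrogen on an aromatic carbon. Within the data shown here, no measured pair isolates this change; compound 3 also carries a bromo group but differs from compound 2 in other places as well, so its value separates nothing. The expected step, a 1.5-fold lower number from compound 2 to compound 4 (0.18 log units; within the scatter), is small, toward a lower number, and not clearly beyond the scatter. Compound 4 is estimated at 1000 nM, within 300 nM to 3500 nM.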

Compound 4, half-maximal inhibitory concentration: 9510 nM
Compound 4: the middle estimate sits 9.5-fold (0.98 log units) below what was measured; measured number above the stated range.
By their numbers in this assay, from the lowest: compounds 3 and 2 (each within the scatter of the next); then compounds 4 and 1 (each within the scatter of the next).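

Bromo in place of hydrogen on this aromatic carbon, ortho to a pentyl group, can now be read in isolation: in this assay it gives a 6.3-fold higher number from compound 2 to compound 4 (0.80 log units; beyond the scatter) and so weakens inhibition. The change at this position is therefore not neutral when the pentyl and 4-methoxybenzyl groups are held fixed. No measurement here accounts for the step.

Still open, on these data alone, is whether chloro, fluoro or a nitrile on this carbon would give a similar step. Also open, as far as these compounds go, is whether bromo would give this step with another group in place of pentyl.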